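Trading a fluorophenyl arm for a short alkenyl chain

The compounds below may be only part of what the source reports. "The series", "measured", "known", "first", "only" and "open" are said of these compounds alone.

Compound 1 `COc1ccc(C(O)(Cc2ccc(F)cc2)c2cccc3ccccc23)c(OC)c1OC` gives 5440 nM in a functional assay on MDA-MB-231 cells (Homo sapiens) for inhibition, read by sulforhodamine B assay, with a stated time of 48 h (a higher number here means a weaker inhibitor, a lower number a stronger inhibitor), the lowest of the two numbers obtained in this set. Compound 2 `COc1ccc(/C(=N/OC(C)=O)c2cccc3ccccc23)c(OC)c1OC` gives 17000 nM in this assay, a gap from compound 1 that lies beyond the usual scatter. Compound 3 `COc1cc(COC(c2ccc(OC)c(OC)c2OC)c2cccc3ccccc23)cc(OC)c1` reaches only a limit of this assay at > 20000 nM, which is the limit of > 20000 nM in this assay, at which 1 of the 3 values shown sits.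

Compound 4 `C=CCC(O)(c1ccc(OC)c(OC)c1OC)c1cccc2ccccc12` has not yet been measured in this assay. It differs from compound 1 in a single place: vinyl in place of 4-fluorophenyl on a saturated chain carbon, two bonds along the chain from two aromatic carbons and an oxygen on a saturated carbon. Within the data shown here, no pair of measured compounds shares this change, so nothing in the data sets its size; what is known is only where compound 1 stands. Replacing an aromatic ring by a short chain is expected to cost some inhibition, but not much more than the scatter, so for compound 4 the estimate is 9000 nM, between 4000 nM and 20000 nM. The expected step is a 1.7-fold higher number from compound 1 to compound 4 (0.22 log units; within the scatter), toward a weaker inhibitor.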

Compound 4, half-maximal inhibitory concentration: > 20000 nM
Compound 4 was reported as a limit; the forecaster's own chance of this, stated with the estimate: 25%; middle value at least 2.2-fold (0.34 log units) from the limit.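

Replacing 4-fluorobenzyl by allyl on the core of compound 1 gives the first step in this set that can be read in one place: it is an at least 3.6-fold higher number from compound 1 to compound 4 (0.56 log units; beyond the scatter) and so lies beyond the scatter, a loss larger than any shown by the earlier compounds, which differ from one another in more than one place. At this position, then, the arm cannot be cut back to the short alkenyl chain without a clear loss of inhibition. Compound 4 gives > 20000 nM in this assay as a limit of the assay and not as a number, so the full size of the step stays unknown, and the limit is now a common result in this set: the limit of > 20000 nM in this assay, at which 2 of the 4 values shown sit.

The compounds shown leave open whether the ring of the arm or its fluorine accounts for the difference. An unsubstituted benzyl or a longer chain such as n-butyl in the same place would separate these two.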